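The source may report more compounds than this note shows. Statements on the series, on what has been measured and on what is new or still open speak of the compounds shown alone.

The measured compounds so far:

Compound 1, `C[C@H](NCc1ccc(OCCCCN2CCN(c3cccc4c3ccn4Cc3cccc(Cl)c3)CC2)cc1)C(N)=O`: 162 nM
Compound 2, `C[C@H](NCc1ccc(OCCCCCCN2CCN(c3cccc4c3ccn4Cc3cccc(Cl)c3)CC2)cc1)C(N)=O`: 340 nM
Compound 3, `C#CCN(C)Cc1ccc(OCCCCN2CCN(c3cccc4c3ccn4Cc3cccc(Cl)c3)CC2)cc1`: 195 nM

All three were tested in an assay on HEK293 cells for displacement of a labelled ligand from 5-hydroxytryptamine receptor 6 (Homo sapiens), read by scintillation counting, with a stated time of 1 h; a higher number here means a weaker inhibitor, a lower number a stronger inhibitor. Compound 1 and compound 2 are built on related cores, but how those two cores differ is not broken down here; what the numbers show is that compound 2 gives a higher number than compound 1, a gap beyond the usual scatter, whereas the values of compound 2 and compound 3 lie within the scatter of each other, so no order can be read between them.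

Compound 3 is derived from compound 1 by a single change, (methyl(propargyl)amino in place of (1-carbamoylethyl)amino on a saturated chain carbon bound to an aromatic carbon). That change produced the step of a 1.2-fold higher number from compound 1 to compound 3 (0.08 log units; within the scatter), so within the scatter the two compounds read alike.

Compound 4, `C#CCN(C)Cc1ccc(OCCCCCCN2CCN(c3cccc4c3ccn4Cc3cccc(Cl)c3)CC2)cc1`, has not yet been measured. It stands to compound 2 exactly as compound 3 stands to compound 1: the change is methyl(propargyl)amino in place of (1-carbamoylethyl)amino on a saturated chain carbon bound to an aromatic carbon, and the place is described in the same words for both pairs, so this is the same change made on the core of compound 2.

The expectation for compound 4 in this assay is therefore a step of a 1.2-fold higher number from compound 2 to compound 4 (0.07 log units; within the scatter), resting on the earlier pair because a 1.2-fold higher number from compound 1 to compound 3 (0.08 log units; within the scatter) was essentially flat. Starting from compound 2 at 340 nM, compound 4 is estimated at 400 nM, most likely falling between 200 nM and 800 nM.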

Compound 4, inhibition constant: 137 nM
Compound 4: the middle estimate sits 2.9-fold (0.47 log units) above what was measured; measured number below the stated range.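

In this assay, putting methyl(propargyl)amino in place of (1-carbamoylethyl)amino on a saturated chain carbon bound to an aromatic carbon gave a 2.5-fold lower number from compound 2 to compound 4 (0.39 log units; beyond the scatter), a modest move towards stronger inhibition. Set beside the earlier pair, the same change did not give the same result on the two cores, so a step measured on one core could not simply be carried over to the other: the same change on two cores in this assay, a 1.2-fold higher number (0.08 log units; within the scatter) from compound 1 to compound 3 and a 2.5-fold lower number (0.39 log units; beyond the scatter) from compound 2 to compound 4, 3.0-fold (0.48 log units) apart, beyond the scatter of two such steps This shows that, for these two pairs, the outcome of the change depends on the core that carries it, but it does not show which feature of the cores is responsible, and two steps give no rule for how the change would behave on any further core.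

The compounds shown carry only these two groups on that carbon, so it remains open how a plain dimethylamino group or a morpholine would read on each core, and whether the triple bond of the propargyl group matters at all. Going by these compounds alone, it also remains open how the change would behave with a longer chain than the one in compound 4.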